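Swapping the aryl group on the shared core

The compounds below may be only part of what the source reports. "The series", "measured", "known", "first", "only" and "open" are said of these compounds alone.

compound 1 `Cc1cc(Nc2cc(N3CCN(C)CC3)nc(Nc3cccc([N+](=O)[O-])c3)n2)n[nH]1`: 962 nM
compound 2 `Cc1cc(Nc2cc(N3CCN(C)CC3)nc(Nc3cccc(Cl)c3)n2)n[nH]1`: 573 nM

In a functional assay on PC-3 cells (Homo sapiens) for antiproliferative activity, read by CCK-8 assay, with a stated time of 72 h (a lower number here means a stronger inhibitor, a higher number a weaker inhibitor), compound 2 gives 573 nM, within the scatter of compound 1 at 962 nM. The next compound to be read is compound 3 `Cc1cc(Nc2cc(N3CCN(C)CC3)nc(Nc3ccc(C#N)cc3)n2)n[nH]1`. Its difference from compound 2 is 4-cyanophenyl in place of 3-chlorophenyl on a nitrogen on an aromatic ring.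

For the measured compounds named here, only one measured step bears on this place: a 1.7-fold lower number from compound 1 to compound 2 (0.23 log units; within the scatter), with chloro in place of nitro on an aromatic carbon. That step stays within the scatter. Going by the values given here, no measured compound carries 4-cyanophenyl, so the evidence is thin and favours neither direction. The expected result is no change beyond the scatter, with an estimated step of a 1.2-fold higher number from compound 2 to compound 3 (0.09 log units; within the scatter). For compound 3 the estimated value in this assay is 700 nM, with an expected range of 300 nM to 1600 nM.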

Compound 3, half-maximal inhibitory concentration: 977 nM
Compound 3: the middle estimate sits 1.4-fold (0.14 log units) below what was measured; low and high end bracket the measured number.
By their numbers in this assay, from the lowest: compounds 2, 1 and 3 (each within the scatter of the next).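

In this assay, for the compounds shown here, the swap to 4-cyanophenyl gives a 1.7-fold higher number from compound 2 to compound 3 (0.23 log units; within the scatter) and, against the nitro compound, a 1.0-fold higher number from compound 1 to compound 3 (0.01 log units; within the scatter) with no step here beyond the scatter. With 3-chlorophenyl, 3-nitrophenyl and 4-cyanophenyl all on a nitrogen on an aromatic ring, the three compounds cannot be told apart at this position, and none goes against that reading. Nothing available explains this flat result or ties it to any property of these groups.

Because substituent and ring position differ together in this change, their separate contributions remain unresolved, and 3-cyanophenyl and 4-chlorophenyl would pull them apart. Also open, on these data alone, is whether a phenyl bearing an amine or a carboxylic acid, or a cyclohexyl group in place of the aryl ring, would give a step beyond the scatter.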